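Iodo in place of furanylcarbonyl: an expected inhibition

This account rests on a few compounds, and the source may have more. Where it says the series, first, only, none or still open, it means among the compounds named here.

Both measured numbers come from an assay on HeLa cells for inhibition of Kinesin-like protein KIF15 (Homo sapiens), read by microscopy, with stated times of 2 s and 20 s, tested at 750 nM; a higher number here means more inhibition at the concentration tested (going by the name of the read-out), a lower number less inhibition.

compound 1 `O=C1Nc2ccc(C(=O)c3ccco3)cc2/C1=C/c1cc(F)c(O)c(F)c1` gives 21%
compound 2 `O=C1Nc2ccc(C(=O)c3ccco3)cc2/C1=C/c1cc(Br)cc(Br)c1` gives 16%

Compound 1 stands highest of the two numbers; its nearest neighbour is compound 2, and the step of a number 5 percentage points lower from compound 1 to compound 2 (within the scatter) lies within the scatter, so no order between the two can be claimed. That step exchanges the group on the double-bonded chain carbon bound to a double-bonded ring carbon and keeps the (furan-2-yl)carbonyl.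

Compound 3 `O=C1Nc2ccc(I)cc2/C1=C/c1cc(F)c(O)c(F)c1` is not yet measured. It differs from compound 1 by iodo in place of (furan-2-yl)carbonyl on an aromatic carbon. Going by the values given here, no measured step touches this place on the shared core; the single step from compound 1 to compound 2 concerns a different group and does not bear on the change at hand. It shows only that the series has so far moved little. With nothing to anchor the direction, the expectation for this assay is a change of no set direction, within the scatter, so that compound 3 is estimated at 20%, with a range from 5% to 40%. The step of a number 1 percentage points lower from compound 1 to compound 3 (within the scatter) is expected, and the wide range reflects the absence of any step through this place.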

Compound 3, a percentage reported as inhibition, at one concentration (the size of the read-out at that concentration, not a potency): 4.8%
Compound 3: middle estimate off by 15.2 percentage points, on the high side, and the stated range ends above it.
By their numbers in this assay, from the lowest: compound 3; then compounds 2 and 1 (each within the scatter of the next).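

In this assay, the step of a number 16.2 percentage points lower from compound 1 to compound 3 (beyond the scatter) makes the aromatic carbon carrying the (furan-2-yl)carbonyl the first place in the series where a single exchange goes beyond the scatter, whereas the earlier step of a number 5 percentage points lower from compound 1 to compound 2 (within the scatter) on the other group does not. With the 3,5-difluoro-4-hydroxyphenyl group held constant, the number at the tested concentration therefore depends on what sits at this place on the shared core, and iodo does not keep the level seen for compound 1 at 21% in this read-out. The furan ring and the carbonyl leave together in this exchange, so the step cannot assign the difference to either part, and nothing measured on these compounds gives a reason for it.

Open, as far as these compounds go, is whether a carbonyl group with a simpler partner, such as acetyl, or a furan ring attached directly without the carbonyl, would stay with compound 1 or fall with compound 3. Also open, from the compounds shown here alone, is how an amine or a carboxylic acid at this aromatic carbon would read, and whether iodo in place of (furan-2-yl)carbonyl gives a similar step when the 3,5-dibromophenyl group of compound 2 is present.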